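Removing One Trifluoromethyl Group in a Pyrazolyl Urea Series

This account rests on a few compounds, and the source may have more. Where it says the series, first, only, none or still open, it means among the compounds named here.

Measured compounds:
compound 1 `O=C(Nc1cccc(-n2cc(-c3ccncc3)c(-c3cc(O)cc(Cl)c3)n2)c1)Nc1ccc(Cl)c(Cl)c1` with -58%
compound 2 `COc1cc(Cl)cc(-c2nn(-c3cccc(NC(=O)Nc4ccc(Cl)c(C(F)(F)F)c4)c3)cc2-c2ccncc2)c1` with -82%
compound 3 `COc1cc(Cl)cc(-c2nn(-c3cccc(NC(=O)Nc4cc(C(F)(F)F)cc(C(F)(F)F)c4)c3)cc2-c2ccncc2)c1` with -63%

Three compounds that share a core and differ in the groups on the terminal aryl of the urea have been measured in a functional assay on SF-295 cells (Homo sapiens) for inhibition, read by sulforhodamine B assay, with a stated time of 48 h, tested at 100 uM; a lower number here means a stronger effect, a higher number a weaker effect of the compound at the concentration tested. Compound 3 stands second highest of the three numbers. Its nearest neighbour is compound 1, whose number is higher by an amount that lies within the scatter, so the two cannot be told apart. Its furthest neighbour is compound 2, whose number is lower by an amount beyond the scatter; compound 2 therefore shows the stronger effect of the two.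

Compound 4 `COc1cc(Cl)cc(-c2nn(-c3cccc(NC(=O)Nc4cccc(C(F)(F)F)c4)c3)cc2-c2ccncc2)c1` has not yet been measured in this assay. It differs from compound 3 in one place: hydrogen in place of trifluoromethyl on an aromatic carbon. One trifluoromethyl group remains on the aryl ring, meta to the place where the other once sat.

For the measured compounds named here, no step between two measured compounds maps this exact change, so the expectation rests on the spread of the three values. The step from compound 3 to compound 4 is expected to be a number 7 percentage points lower from compound 3 to compound 4 (within the scatter), small and within the scatter, leaning if at all toward a lower number. Compound 4 is expected to give -70%, with a range from -95% to -45%.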

Compound 4, a percentage reported as activity, at one concentration (the size of the read-out at that concentration, not a potency): -53%
Estimate against measurement, compound 4: 17 percentage points below; the measured number falls inside the stated range.
By their numbers in this assay, from the lowest: compound 2; then compounds 3, 1 and 4 (each within the scatter of the next).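

In this assay the exchange of trifluoromethyl for hydrogen gives a number 10 percentage points higher from compound 3 to compound 4 (within the scatter) and so leaves no difference that this read-out can resolve: on this aromatic carbon, the second trifluoromethyl group can go while the effect at the tested concentration stays indistinguishable from that of compound 3. Hydrogen in place of chloro on the aryl ring gives a number 29 percentage points higher from compound 2 to compound 4 (beyond the scatter) and is the only one of the two steps that lies beyond the scatter, showing that the group paired with the remaining trifluoromethyl can matter on this ring, with compound 2 giving the stronger effect and compound 4 the weaker. The data shown offer no measurement that would explain either step.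

What the compounds shown leave open is how an amine, a nitrile or a carboxylic acid on the same aromatic carbon would read in this assay when set against hydrogen and trifluoromethyl. They also leave open whether the two steps would look the same at lower concentrations, as each compound here has a reading at one concentration only and no potency.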